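The source may hold more compounds than are shown below. What is called first, only, known or untested is meant among the compounds shown, and "the series" means these compounds.

Measured so far in a functional assay on isolated protein for antagonist activity at C-C chemokine receptor type 9 (Homo sapiens), read by calcium flux, with a stated time of 10 min; a lower number here means a stronger inhibitor, a higher number a weaker inhibitor:
compound 1, `CC(C)(C)c1ccc(S(=O)(=O)Nc2ccc(Cl)cc2-c2ncncc2N)cc1`: 3.2 nM
compound 2, `CN(C)c1ncnc(-c2cc(Cl)ccc2NS(=O)(=O)c2ccc(C(C)(C)C)cc2)c1O`: 9 nM
compound 3, `CC(C)(C)c1ccc(S(=O)(=O)Nc2ccc(Cl)cc2-c2ncnc(CO)c2O)cc1`: 11 nM

Compound 3 sits at the upper end of these numbers: the step of a 3.4-fold higher number from compound 1 to compound 3 (0.54 log units; beyond the scatter) is beyond the scatter, whereas a 1.2-fold higher number from compound 2 to compound 3 (0.09 log units; within the scatter) is within it, so compounds 2 and 3 read alike. Compound 4, `CC(C)(C)c1ccc(S(=O)(=O)Nc2ccc(Cl)cc2-c2nccnc2NCCO)cc1`, differs from compound 3 by a group of 10 heavy atoms (6 carbon, 3 nitrogen, 1 oxygen; one six-membered aromatic ring with 2 hetero atoms) in place of a group of 9 heavy atoms (5 carbon, 2 nitrogen, 2 oxygen; one six-membered aromatic ring with 2 hetero atoms), on an aromatic carbon, ortho to a large group and meta to a chloro group. Among the compounds with values here, the steps that bear on this are the ring swaps from compound 1, a 2.8-fold higher number from compound 1 to compound 2 (0.45 log units; beyond the scatter) and a 3.4-fold higher number from compound 1 to compound 3 (0.54 log units; beyond the scatter), both modest and both upward, and the exchange a 1.2-fold higher number from compound 2 to compound 3 (0.09 log units; within the scatter), which changed nothing beyond the scatter. A further exchange of this kind is expected to leave this assay near compound 3, with no step beyond the scatter. The estimated step is a 1.1-fold higher number from compound 3 to compound 4 (0.04 log units; within the scatter). Compound 4 is expected at 12 nM, in the range 4 nM to 35 nM.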

Compound 4, half-maximal inhibitory concentration: 34 nM
For compound 4 the middle estimate is 2.8-fold (0.45 log units) below the measured one; the measured number falls inside the stated range.
By their numbers in this assay, from the lowest: compound 1; then compounds 2 and 3 (each within the scatter of the next); then compound 4.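

In this assay, the group entering in compound 4 has the same heavy atom count and atom types as the group in compound 2, yet the number still moves beyond the scatter (a 3.8-fold higher number from compound 2 to compound 4 (0.58 log units; beyond the scatter)), so composition alone does not set the reading at this position. The same holds against compound 3 (a 3.1-fold higher number from compound 3 to compound 4 (0.49 log units; beyond the scatter)), although compounds 2 and 3 read alike. The gap from the core of compound 1 now reaches a large step (an 11-fold higher number from compound 1 to compound 4 (1.03 log units; beyond the scatter)), and nothing available accounts for these steps. Still open, as far as these compounds go, is whether a carboxylic acid or a longer chain on this ring would bring the number back toward compound 1 or raise it further.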